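A few compounds are considered here, and "the series" means these few. Any claim that something is new, unique, unknown or untested is made for them only; others in the source may bear on it.

Among the compounds with values here, compound 3 `Cc1ccccc1CC[C@H](O)CC[C@@H]1[C@@H](CCCCCCC(=O)O)[C@@H](O)C[C@H]1O` is one of three compounds measured in an in vitro assay on CHO-KI cells for displacement of a labelled ligand from prostaglandin E2 receptor EP3 subtype (Homo sapiens); a higher number here means a weaker inhibitor, a lower number a stronger inhibitor. In this assay compound 3 reaches only the limit of the assay, > 10000 nM, and not a number. Compound 2 `O=C(O)CCCCCC[C@@H]1[C@@H](CC[C@@H](O)CCc2ccc(F)cc2)[C@H](O)C[C@@H]1O` likewise sits at the limit of the assay, > 10000 nM. Compound 1 `O=C(O)CCCCCC[C@@H]1[C@@H](CC[C@@H](O)CCc2cccc(F)c2)[C@H](O)C[C@@H]1O` gives 3700 nM in this assay. The step of an at least 2.7-fold higher number from compound 1 to compound 3 (0.43 log units; beyond the scatter) and the step of an at least 2.7-fold higher number from compound 1 to compound 2 (0.43 log units; beyond the scatter) both rest on (the limit of > 10000 nM in this assay, at which 2 of the 3 values shown sit), and the step that the two limits leave unreadable from compound 2 to compound 3 cannot be read. Compound 4 `COc1ccc(CC[C@H](O)CC[C@@H]2[C@@H](CCCCCCC(=O)O)[C@@H](O)C[C@H]2O)cc1` differs from compound 3 by 4-methoxyphenyl in place of 2-methylphenyl on a saturated chain carbon, three bonds along the chain from an oxygen on a saturated carbon. Within the data shown here, no measured step exchanges a methyl group for a methoxy group, so the change from compound 3 to compound 4 can only be judged against the limit at which compound 3 stands. Compound 4 is therefore expected to sit near that limit, with the step of an at least 1.1-fold lower number from compound 3 to compound 4 (0.04 log units; that floor lies within the scatter) expected to stay within the scatter. Compound 4 is estimated at 9000 nM in this assay, with a range from 3000 nM to 30000 nM.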

Compound 4, half-maximal inhibitory concentration: > 10000 nM
Compound 4: a limit, no number (the forecaster's own chance of this, stated with the estimate: 50%); middle value at least 1.1-fold (0.04 log units) away from the limit.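

In this assay compound 4 also stands at a limit of the assay, > 10000 nM, and not at a number. A third aromatic group at this place, 4-methoxyphenyl, which brings an oxygen that the earlier groups lack, thus gives an at least 2.7-fold higher number from compound 1 to compound 4 (0.43 log units; beyond the scatter), and compound 1, with 3-fluorophenyl, remains the only compound shown with a number. The steps from compound 2 and from compound 3 to compound 4 cannot be read, because of where the values stand: the limit of > 10000 nM in this assay, at which 3 of the 4 values shown sit.

Going by these compounds, how far compound 2, compound 3 and compound 4 lie past the limit stays open, so no order among them can be given. Also open, on these data alone, is whether a chloro group or an amine in place of the fluoro of compound 1 would keep a value with a number.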